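Thiourea-linked sulfonamides tested against NCI-H1975 cells

The source may hold more compounds than are shown below. What is called first, only, known or untested is meant among the compounds shown, and "the series" means these compounds.

Of the compounds shown here, two have been measured in a functional assay on NCI-H1975 cells (Homo sapiens) for antiproliferative activity, read by MTT assay, with a stated time of 72 h; on this read-out higher numbers stand for weaker inhibition and lower numbers for stronger inhibition. Compound 1, `CCc1ccc(Nc2ncnc3cc(OC)c(OCCCCC(=O)Nc4ccc(S(N)(=O)=O)cc4)cc23)cc1`, gives 10300 nM. Compound 2, `NS(=O)(=O)c1ccc(NC(=S)Nc2ccc3ncnc(Nc4ccc(F)c(Br)c4)c3c2)cc1`, gives 9980 nM. The number for compound 2 is the lower of the two, but the gap to compound 1 lies within the scatter, so the two values cannot be told apart.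

Compound 3, `Cc1ccc(Nc2ncnc3ccc(NC(=S)Nc4ccc(S(N)(=O)=O)cc4)cc23)cc1`, has not been measured. It differs from compound 2 in one place: 4-methylphenyl in place of 3-bromo-4-fluorophenyl on a nitrogen on an aromatic ring. Among the measured compounds shown here, no measured pair shows this change, so its effect is unknown. Both measured values sit in the same narrow region, and nothing in the data points to a move beyond the scatter. The step from compound 2 to compound 3 is therefore expected to be small, a 1.5-fold higher number from compound 2 to compound 3 (0.18 log units; within the scatter), with a slight lean toward a higher number. Compound 3 is estimated at 15000 nM, in the range 5000 nM to 50000 nM.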

Compound 3, half-maximal inhibitory concentration: 39400 nM
Compound 3: middle estimate off by 2.6-fold (0.42 log units), on the low side; low and high end bracket the measured number.
By their numbers in this assay, from the lowest: compounds 2 and 1 (each within the scatter of the next); then compound 3.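

At the position on a nitrogen on an aromatic ring, the choice of aryl group matters in this assay: 4-methylphenyl in place of 3-bromo-4-fluorophenyl gives a 3.9-fold higher number from compound 2 to compound 3 (0.60 log units; beyond the scatter). Among the compounds shown here, this is the first single change that can be read, and it separates compounds that had so far all sat within the scatter of one another, showing that the thiourea-linked scaffold does respond to this group. Nothing at hand speaks to why the number rises.

As far as these compounds go, the change removes bromine and fluorine and adds methyl in one step, so it remains open whether 3-bromophenyl, 4-fluorophenyl or plain phenyl would sit closer to compound 2 or to compound 3. From the compounds shown here alone, it is also open whether the same change would move the number on the core of compound 1.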